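Compound 3 gains a (methylsulfonyl)methyl group

The source may report more compounds than this note shows. Statements on the series, on what has been measured and on what is new or still open speak of the compounds shown alone.

In a physicochemical assay for lipophilicity (a higher number here means a more lipophilic compound, a lower number a more polar compound), compound 3 (`Oc1cccc(-c2nccc([C@]34CCOC[C@H]3C4)n2)c1`) gives 4 and stands level with its mirror image, compound 2 (`Oc1cccc(-c2nccc([C@@]34CCOC[C@@H]3C4)n2)c1`), which gives 4 as well. Compound 4 (`CS(=O)(=O)Cc1cc([C@]23CCOC[C@H]2C3)nc(-c2cccc(O)c2)n1`) has (methylsulfonyl)methyl in place of hydrogen on an aromatic carbon. For the measured compounds named here, the single measured step gives no change at the digits printed from compound 2 to compound 3 (within the scatter) and concerns only configuration (the fact that compounds 2 and 3 differ only in the configuration as drawn), so it does not bear on this group. Compound 1 (`CS(=O)(=O)Cc1cc(C2=CCOCC2)nc(-c2cccc(O)c2)n1`) also bears (methylsulfonyl)methyl and gives 3.3 in this assay beyond the scatter below compound 3, so a fall is expected. The estimated a number 0.60 log units lower from compound 3 to compound 4 (beyond the scatter) is expected to exceed the scatter. Compound 4 is expected at 3.4 within an estimated range of 2.9 to 3.9 when measured.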

Compound 4, partition coefficient: 3.7
Estimate against measurement, compound 4: 0.30 log units below; measured number inside the range.
By their numbers in this assay, from the lowest: compound 1; then compounds 4, 2 and 3 (each within the scatter of the next).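

In this assay, (methylsulfonyl)methyl in place of hydrogen on this aromatic carbon gives a number 0.30 log units lower from compound 3 to compound 4 (within the scatter), so the group is not shown to shift the number at this position. With that group present, the group of 7 heavy atoms in place of the group of 6 heavy atoms gives a number 0.40 log units higher from compound 1 to compound 4 (beyond the scatter), a modest step and the first measured for this exchange. Nothing given here offers a cause for either step.

Going by these compounds, it remains open whether an amine or a carboxylic acid on this aromatic carbon would give a step beyond the scatter. Also open, on these data alone, is whether the mirror image of compound 4 would stand level with it, as compound 2 does with compound 3.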